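This account rests on a few compounds, and the source may have more. Where it says the series, first, only, none or still open, it means among the compounds named here.

Measured so far:
Compound 2 `COc1ccc([C@@H]2CC(=O)c3c(O)cc(OCc4cn(Cc5ccccc5)nn4)cc3O2)cc1O` — 11000 nM
Compound 1 `COc1ccc([C@@H]2CC(=O)c3c(O)cc(OCc4cn(Cc5ccc(C(F)(F)F)cc5)nn4)cc3O2)cc1O` — 17700 nM

Two compounds share the same core and differ only on the phenyl ring of the benzyl group. In a functional assay on RAW264.7 cells (Mus musculus) for inhibition, read by Griess assay, with stated times of 2 h and 24 h (a lower number here means a stronger inhibitor, a higher number a weaker inhibitor), compound 2 gives 11000 nM. Compound 1, which carries a trifluoromethyl on that ring, gives 17700 nM. The step between them, a 1.6-fold lower number from compound 1 to compound 2 (0.21 log units; within the scatter), cannot be told apart from repeat-measurement noise, so on the numbers shown compound 2 stands at one end of a pair that is effectively level.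

Compound 3 `COc1ccc([C@@H]2CC(=O)c3c(O)cc(OCc4cn(Cc5ccccc5F)nn4)cc3O2)cc1O` has not yet been measured. It differs from compound 2 by fluoro in place of hydrogen on an aromatic carbon. Going by the values given here, the only measured step that bears on this change is the one on the same ring, from trifluoromethyl to hydrogen, and it stayed within the scatter. A single fluoro on that ring is therefore expected to move the number little: compound 3 is expected to give 10000 nM, within a range of 4000 nM to 25000 nM. The expected step is a 1.1-fold lower number from compound 2 to compound 3 (0.04 log units; within the scatter).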

Compound 3, half-maximal inhibitory concentration: 7320 nM
Beside the measured number, compound 3's estimate is 1.4-fold (0.14 log units) above it; the range from low to high includes it.
By their numbers in this assay, from the lowest: compounds 3, 2 and 1 (each within the scatter of the next, the first and the last beyond it).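

In this assay, placing fluoro on an aromatic carbon ortho to a large group, which turns benzyl into 2-fluorobenzyl, gives a 1.5-fold lower number from compound 2 to compound 3 (0.18 log units; within the scatter), so this position accepts the small atom without a step that can be told apart from repeat-measurement noise. Going by these compounds alone, the same ring also gives the first step in this set that clears the scatter: swapping 4-(trifluoromethyl)phenyl for 2-fluorophenyl gives a 2.4-fold lower number from compound 1 to compound 3 (0.38 log units; beyond the scatter), a modest separation, while compound 2 stays within the scatter of both neighbours. Nothing shown explains why these two compounds separate.

On these data alone, it remains open whether fluoro at other places on this ring would read the same as in compound 3. Also open, as far as these compounds go, is how an amine or a carboxylic acid on this ring, or a longer chain in place of the benzyl group, would behave.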